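The source may report more compounds than this note shows. Statements on the series, on what has been measured and on what is new or still open speak of the compounds shown alone.

In an in vitro ADME assay on microsomes from liver (Rattus norvegicus) for metabolic stability (on this read-out higher numbers stand for fast clearance and lower numbers for slow clearance), compound 1 `CC(C)NC(=O)[C@H]1CC[C@@H](n2/c(=N/C(=O)c3ccccc3)[nH]c3ccc(CN4CCCCC4)cc32)CC1` gives 389 mL.min-1.g-1. In this assay, compound 2 `CC(C)NC(=O)[C@H]1CC[C@@H](n2/c(=N/C(=O)c3ccncc3)[nH]c3ccc(CN4CCC(C(C)(C)O)CC4)cc32)CC1` gives < 14 mL.min-1.g-1, and this figure is a limit of the assay, not a number. Compound 2 therefore has no exact position and sits at the slow-clearance end of the two results in hand.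

Compound 3 `CC(C)NC(=O)[C@H]1CC[C@@H](n2/c(=N/C(=O)c3ccccc3)[nH]c3ccc(CN4CCC(C(C)(C)O)CC4)cc32)CC1` differs from compound 2 in one place, with phenyl in place of pyridin-4-yl on a carbonyl carbon. Going by the values given here, no measured pair of compounds shows this change alone, so the size of the step has to be judged with caution. The only available hint is that compound 1, which also carries phenyl in that place, gives 389 mL.min-1.g-1 in this assay. On that basis, a moderate rise towards faster clearance seems more likely than no change, though nothing close to the full distance up to that value is expected. The estimated change is an at least 2.5-fold higher number from compound 2 to compound 3 (0.39 log units; beyond the scatter), in the direction of faster clearance. Compound 3 is expected to give about 35 mL.min-1.g-1, with an estimated range of 14 mL.min-1.g-1 to 110 mL.min-1.g-1.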

Compound 3, intrinsic clearance in microsomes: 21 mL.min-1.g-1
For compound 3 the middle estimate is 1.7-fold (0.22 log units) above the measured one; measured number inside the range.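

In this assay, going by these compounds alone, the first single-place comparison with two real numbers is a 19-fold lower number from compound 1 to compound 3 (1.27 log units; beyond the scatter); it comes with 1-hydroxy-1-methylethyl in place of hydrogen on a saturated ring carbon, while the phenyl on the carbonyl carbon stays the same. The other new comparison, with phenyl in place of pyridin-4-yl on a carbonyl carbon, is an at least 1.5-fold higher number from compound 2 to compound 3 (0.17 log units; that floor lies within the scatter), so compound 3 keeps the phenyl of compound 1 and still stays far from the fast-clearance value of compound 1. The size of this second step cannot be read more closely, and no real rise can be claimed, because the result for compound 2 is a limit of the assay and not a number: the limit of < 14 mL.min-1.g-1 in this assay, at which 1 of the 3 values shown sits.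

From the compounds shown here alone, it remains open whether a smaller group on the same saturated ring carbon, such as hydroxyl or methoxy, would go with a drop of similar size, and whether the 1-hydroxy-1-methylethyl step would be as large with pyridin-4-yl on the carbonyl carbon. Going by these compounds, how a different ring there, such as pyridin-3-yl or thiophene, would compare with phenyl also remains open.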